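Stereochemical Inversion at the Ring Carbon of Compound 1

The source may report more compounds than this note shows. Statements on the series, on what has been measured and on what is new or still open speak of the compounds shown alone.

Measured compounds:
compound 1, `CCCCCCCCCCCOc1ccccc1CCC(=O)OC[C@H]1OCC=C[C@@H]1OP(=O)(O)OC[C@H](N)C(=O)O`, "not active" (no number reported)
compound 2, `N[C@@H](COP(=O)(O)O[C@@H]1C=CCO[C@@H]1COC(=O)CCc1ccccc1OCc1cccc(Oc2ccccc2)c1)C(=O)O`, 0.2
compound 3, `CCCCCCCC/C=C\CCCCCCCC(=O)O[C@H]1CCCO[C@@H]1COP(=O)(O)OC[C@H](N)C(=O)O`, "not active" (no number reported)

The study concerns an assay on HEK293-A cells with probable G-protein coupled receptor 34 (Mus musculus) as the target, with a stated time of 1.5 h; a higher number here means a larger maximal response, a lower number a smaller maximal response. Compound 1 gives "not active" (no number reported) in this assay, so no number stands for it. Compound 3 likewise gives "not active" (no number reported) in this assay. Within the data shown here, compound 2, the only one with a reported number, gives 0.2 in this assay. Compound 1 therefore stands among the two compounds without a response, with a single numbered neighbour in compound 2 for comparison.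

Compound 4, `CCCCCCCCCCCOc1ccccc1CCC(=O)OC[C@H]1OCC=C[C@H]1OP(=O)(O)OC[C@H](N)C(=O)O`, has yet to be measured in this assay. The change from compound 1 to compound 4 is the two compounds have the same atoms and bonds; at least one stereo element is drawn with a configuration in one of them and without one in the other: 1 of 4 stereo elements differ; a stereocentre at a saturated ring carbon is drawn S in compound 1 and R in compound 4. Among the measured compounds shown here, no step between two measured compounds is available that would show what such an inversion does, and compound 1 itself carries no number to step from. Since compound 1 gives "not active" (no number reported) in this assay, the expectation is that compound 4 will also show little or no response, with a moderate chance that again no number is reported. Compound 4 is estimated at 0.1 in this assay, within a range of 0 to 0.3.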

Compound 4, intrinsic activity: the largest response reached, as a fraction of the reference agonist's: 0.086
Estimate against measurement, compound 4: 0.014 above; the measured number falls inside the stated range.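

Among these compounds, compound 1 gives "not active" (no number reported) in this assay, so no step from compound 1 to compound 4 can be read, even though compound 4 gives 0.086. The compounds shown leave open what inverting the stereocentre at the saturated ring carbon does to the maximal response, and one further caution applies to this pair: the fact that one of compounds 1 and 4 is drawn with a defined configuration and the other without, at the place where they differ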